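This account rests on a few compounds, and the source may have more. Where it says the series, first, only, none or still open, it means among the compounds named here.

Measured compounds:
- compound 1, `Cc1ccc2oc(C(=O)Nc3nnn[nH]3)cc(=O)c2c1` — 0.075 ug/mL
- compound 2, `O=C(Nc1nc[nH]n1)c1cc(=O)c2ccccc2o1` — 5 ug/mL

Both compounds were run in a functional assay on cells (Mast cell, Rattus norvegicus) for inhibition, with a stated time of 15 min; a higher number here means that more compound is needed for the effect, a lower number that less compound is needed. Compound 1 gives 0.075 ug/mL, and compound 2 gives 5 ug/mL, the highest of the two numbers; the gap between the two values lies beyond the scatter, with compound 1 at the lower number. The two compounds differ in more than one place, so no single step is listed between them.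

Compound 3, `Cn1nnnc1NC(=O)c1cc(=O)c2ccccc2o1`, has not been measured. Its difference from compound 2 is 1-methyl-1H-tetrazol-5-yl in place of 1H-1,2,4-triazol-3-yl on an amide-type nitrogen. The amide-type nitrogen thereby carries a ring with 4 hetero atoms and 0 hydrogen-bond donors instead of one with 3 hetero atoms and 1 hydrogen-bond donor. Among the measured compounds shown here, no measured pair shows this change on its own, and compound 1, the only other point, carries a different ring with a hydrogen-bond donor, so it gives no direct guide.

In this assay a step from compound 2 to compound 3 of moderate size towards a higher number is expected, though a result within the scatter cannot be excluded. The expected step is a 2.4-fold higher number from compound 2 to compound 3 (0.38 log units; beyond the scatter). Compound 3 is estimated at 12 ug/mL, with a range from 2.5 ug/mL to 60 ug/mL.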

Compound 3, concentration for half-maximal effect: > 18 ug/mL
Compound 3 gave a limit, no number; the forecaster's own chance of this, stated with the estimate: 25%; middle value at least 1.5-fold (0.17 log units) away from the limit.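

In this assay compound 3 gives > 18 ug/mL, which is a limit of the assay and not a number. Among the compounds shown here, on the amide-type nitrogen, 1-methyl-1H-tetrazol-5-yl in place of 1H-1,2,4-triazol-3-yl gives an at least 3.6-fold higher number from compound 2 to compound 3 (0.55 log units; beyond the scatter), so this position is not indifferent to the exchange, at least in this single pair, which is the first comparison that differs in one place. The exchange alters the hetero atom count, the hydrogen-bond donor count and the methyl group at once, and the true size of the step stays unresolved, with only its lower bound fixed by the result: the limit of > 18 ug/mL in this assay, at which 1 of the 3 values shown sits.

The compounds shown do not separate the contribution of the methyl group from that of the ring change, and compound 1 differs from both other compounds in more than one place, so it cannot settle this point. Also open, on these data alone, is how the same amide-type nitrogen on the core of compound 2 would respond to a ring with no hetero atoms, such as phenyl, or to a phenyl ring bearing a carboxylic acid.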